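The source may report more compounds than this note shows. Statements on the series, on what has been measured and on what is new or still open speak of the compounds shown alone.

In an ADME assay on Huh-7 cells (Homo sapiens) for cytotoxicity, read by XTT assay (a lower number here means that less compound is tolerated, a higher number that more compound is tolerated), compound 3 `O=C(OC[C@H]1O[C@@H](n2cnc3c(Cl)ncnc32)[C@H](O)[C@@H]1O)c1ccccc1` gives 97300 nM. Compound 1 `O=C(OC[C@H]1C[C@@H](n2cnc3c(Cl)ncnc32)[C@@H]1CO)c1ccccc1` gives 20000 nM, so compound 3 holds the higher of these two numbers, by a gap beyond the scatter. Compound 2 `OC[C@H]1C[C@@H](n2cnc3c(Cl)ncnc32)[C@@H]1CO` gives > 200000 nM, which is a limit of the assay and not a number.

Compound 4 `O=C(OC[C@@H]1C[C@@H](O)[C@H](n2cnc3c(Cl)ncnc32)O1)c1ccccc1` has not yet been measured. It differs from compound 3 by a single change, hydrogen in place of hydroxy on a saturated ring carbon. Among the measured compounds shown here, only one measured step is available, an at least 10-fold higher number from compound 1 to compound 2 (1.00 log units; beyond the scatter). That step removes a benzoyl group, which is a different change, so it shows only that one edit can move this assay clearly and gives no direct measure for this one. Compound 4 keeps the benzoyl group, and compound 1, which also carries it, stands at 20000 nM. A small shift toward lower numbers is therefore expected, possibly not beyond the scatter. The expected step is a 1.5-fold lower number from compound 3 to compound 4 (0.18 log units; within the scatter). For compound 4 the estimate is 65000 nM, with an expected range of 22000 nM to 190000 nM.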

Compound 4, half-maximal cytotoxic concentration: 70500 nM
Compound 4: middle estimate off by 1.1-fold (0.04 log units), on the low side; low and high end bracket the measured number.
By their numbers in this assay, from the lowest: compound 1; then compounds 4 and 3 (each within the scatter of the next). At a limit, above all of these: compound 2.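

Removing the hydroxy from this saturated ring carbon, with hydrogen taking its place, gives in this assay a 1.4-fold lower number from compound 3 to compound 4 (0.14 log units; within the scatter). This is the first step shown at this position, and it shows that this single change, made on a five-membered non-aromatic ring with 1 oxygen, leaves the reading within the scatter, whereas the only earlier step concerned the removal of a benzoyl group, a different change. Nothing measured here bears on why the reading stays within the scatter.

Only hydroxy and hydrogen are shown on this ring carbon, so how an amine or a methoxy group there would read in this assay remains open. As far as these compounds go, compound 3 and compound 4 both carry the benzoyl group, and whether the same change would read alike without it is also open.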